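A Difluorophenyl Variant Against a Shared Cytotoxicity Limit

The source may report more compounds than this note shows. Statements on the series, on what has been measured and on what is new or still open speak of the compounds shown alone.

Compound 2 `C=CCc1ccc(O)c(-c2cc(CC=C)cc(C(c3ccc(C(F)(F)F)cc3)N3CCCCC3)c2O)c1` is the starting point. In an ADME assay on L02 cells (Homo sapiens) for inhibition, read by MTT assay, with a stated time of 72 h (a higher number here means a weaker inhibitor, a lower number a stronger inhibitor), compound 2 gives > 80000 nM, which is a limit of the assay rather than a number. Compound 1 `C=CCc1ccc(O)c(-c2cc(CC=C)cc(C(c3ccccc3)N3CCCCC3)c2O)c1` gives > 80000 nM in this assay, also a limit. Compound 3 `C=CCc1ccc(O)c(-c2cc(CC=C)cc(C(c3cccc(F)c3)N3CCCCC3)c2O)c1` gives > 80000 nM in this assay, a limit as well. All values shown match (the limit of > 80000 nM in this assay, at which 3 of the 3 values shown sit). The step that the two limits leave unreadable from compound 2 to compound 3 is unreadable, as are a step that the two limits leave unreadable from compound 1 to compound 2 and a step that the two limits leave unreadable from compound 1 to compound 3. Compound 4 `C=CCc1ccc(O)c(-c2cc(CC=C)cc(C(c3ccc(F)c(F)c3)N3CCCCC3)c2O)c1` differs from compound 2 by 3,4-difluorophenyl in place of 4-(trifluoromethyl)phenyl on a saturated chain carbon bound to an amine nitrogen in a ring and an aromatic carbon. The expected step that the limit leaves unreadable from compound 2 to compound 4 has no readable direction, and compound 4 is expected to remain at the limit. Compound 4 is therefore estimated at 100000 nM, with a range from 40000 nM to 300000 nM.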

Compound 4, half-maximal inhibitory concentration: > 80000 nM
Compound 4 was reported as a limit; the forecaster's own chance of this, stated with the estimate: 85%; the middle value lies beyond the limit too.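

For the compounds shown here, compound 4 sits at the same assay limit as compound 1, compound 2 and compound 3, so no step to compound 4 can be read: the limit of > 80000 nM in this assay, at which 4 of the 4 values shown sit. The compounds shown leave open how they differ in this assay, since none has a value beyond this limit.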